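A few compounds are considered here, and "the series" means these few. Any claim that something is new, unique, unknown or untested is made for them only; others in the source may bear on it.

Measured in a functional assay on P388 cells (Mus musculus) for cytotoxicity; a higher number here means a weaker inhibitor, a lower number a stronger inhibitor:
- compound 1 `COc1ccc2cc1Oc1ccc(cc1)C[C@H]1C(=O)N(C)[C@@H](C2)C(=O)N[C@H](C)C(=O)N[C@@H](C)C(=O)N(C)[C@@H](Cc2ccccc2)C(=O)N[C@@H](C)C(=O)N1C`: 295 nM
- compound 2 `COc1ccc2cc1Oc1ccc(cc1)C[C@H]1C(=O)N(C)[C@@H](C2)C(=O)N[C@H](C)C(=O)N[C@@H](C)C(=O)N(C)[C@@H](Cc2ccc(C)cc2)C(=O)N[C@@H](C)C(=O)N1C`: 24 nM
- compound 3 `C/C=C/c1ccc(C[C@H]2C(=O)N[C@@H](C)C(=O)N(C)[C@H]3Cc4ccc(cc4)Oc4cc(ccc4OC)C[C@@H](C(=O)N[C@H](C)C(=O)N[C@@H](C)C(=O)N2C)N(C)C3=O)cc1`: 5.01 nM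

Compound 3 has the lowest number of the three, and the nearest is compound 2, with a 4.8-fold lower number from compound 2 to compound 3 (0.68 log units; beyond the scatter) separating them. In compound 4 `COc1ccc(C[C@H]2C(=O)N[C@@H](C)C(=O)N(C)[C@H]3Cc4ccc(cc4)Oc4cc(ccc4OC)C[C@@H](C(=O)N[C@H](C)C(=O)N[C@@H](C)C(=O)N2C)N(C)C3=O)cc1O`, 3-hydroxy-4-methoxyphenyl stands in place of 4-(prop-1-en-1-yl)phenyl on a saturated chain carbon bound to a saturated ring carbon: 3-hydroxy-4-methoxyphenyl in place of 4-(prop-1-en-1-yl)phenyl on a saturated chain carbon bound to a saturated ring carbon.

Among the compounds with values here, three measured steps bear on this, all made on the same aromatic ring. The first, a 12-fold lower number from compound 1 to compound 2 (1.09 log units; beyond the scatter), is large, as is a 59-fold lower number from compound 1 to compound 3 (1.77 log units; beyond the scatter), while a 4.8-fold lower number from compound 2 to compound 3 (0.68 log units; beyond the scatter) is modest. None of them involves a hydroxy or methoxy group, so the data give no direct measure of this replacement. Compound 4 gives up the prop-1-en-1-yl group of compound 3, so a modest to large rise in the number is expected, though probably not all the way to compound 1 at 295 nM. The expected change is an 8.0-fold higher number from compound 3 to compound 4 (0.90 log units; beyond the scatter). For compound 4 the estimated value is 40 nM, with an expected range from 8 nM to 200 nM.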

Compound 4, half-maximal inhibitory concentration: 214 nM
For compound 4 the middle estimate is 5.4-fold (0.73 log units) below the measured one; measured number above the stated range.
By their numbers in this assay, from the lowest: compound 3; then compound 2; then compounds 4 and 1 (each within the scatter of the next).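

In this assay the step of a 43-fold higher number from compound 3 to compound 4 (1.63 log units; beyond the scatter) is large, and the step of an 8.9-fold higher number from compound 2 to compound 4 (0.95 log units; beyond the scatter) shows that 3-hydroxy-4-methoxyphenyl also falls short of 4-methylphenyl at this position. The step of a 1.4-fold lower number from compound 1 to compound 4 (0.14 log units; within the scatter) lies within the scatter, so this ring with its hydroxy and methoxy groups cannot be told apart from plain phenyl, whereas the methyl and prop-1-en-1-yl groups of compound 2 and compound 3 each moved the number well beyond the scatter. Nothing available gives a reason for this result.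

As far as these compounds go, whether the hydroxy or the methoxy group alone would behave in the same way stays open. So does whether the double bond of the prop-1-en-1-yl group matters, which a saturated propyl chain could test, and how an amine on the ring would fare.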